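A few compounds are considered here, and "the series" means these few. Any claim that something is new, unique, unknown or untested is made for them only; others in the source may bear on it.

Compound 3 `CC(=O)NS(=O)(=O)c1ccc(-n2nc(-c3ccccc3)cc2-c2cc(O)ccc2O)cc1` gives 100000 nM in a functional assay on cells (Cancer cell lines, Homo sapiens) for cytotoxicity, read by sulforhodamine B assay, with a stated time of 48 h (a lower number here means a stronger inhibitor of growth, a higher number a weaker inhibitor of growth), the highest of the three numbers measured. Its nearest neighbour is compound 2 `Oc1ccc(O)c(-c2cc(-c3ccccc3)nn2-c2ccccc2)c1`, which gives 63700 nM; the step of a 1.6-fold higher number from compound 2 to compound 3 (0.20 log units; within the scatter) lies within the scatter. Compound 1 `COc1ccc(OC)c(-c2cc(-c3ccccc3)nn2-c2ccc(S(=O)(=O)NC(C)=O)cc2)c1` gives 49800 nM, and the step of a 2.0-fold higher number from compound 1 to compound 3 (0.30 log units; within the scatter) is likewise within the scatter. Among the measured compounds shown here, all three compounds therefore sit close together, and no measured step among them reaches beyond the scatter.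

Compound 4 `CC(=O)NS(=O)(=O)c1ccc(-n2nc(-c3ccccc3)cc2C2=CC(=O)C=CC2=O)cc1` differs from compound 3 in one place: a group of 8 heavy atoms (6 carbon, 2 oxygen; one six-membered non-aromatic ring of carbon only) in place of a group of 8 heavy atoms (6 carbon, 2 oxygen; one six-membered aromatic ring of carbon only), on an aromatic carbon. For the measured compounds named here, no measured pair carries this exact change. The step that bears on it most closely is a 2.0-fold higher number from compound 1 to compound 3 (0.30 log units; within the scatter), which also replaced the group on an aromatic carbon of the same ring and moved the number by no more than the scatter. The step of a 1.6-fold higher number from compound 2 to compound 3 (0.20 log units; within the scatter) shows that a change elsewhere in the molecule was small as well. On that basis the step of a 1.7-fold lower number from compound 3 to compound 4 (0.22 log units; within the scatter) is expected to remain within the scatter, with no clear direction. The estimate for compound 4 is accordingly 60000 nM, with a range from 20000 nM to 180000 nM.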

Compound 4, concentration for total growth inhibition: 100000 nM
For compound 4 the middle estimate is 1.7-fold (0.22 log units) below the measured one, and the stated range covers the measured number.
By their numbers in this assay, from the lowest: compounds 1, 2, 3 and 4 (each within the scatter of the next).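

Among the compounds shown here, at this position, on an aromatic carbon of a five-membered aromatic ring with 2 nitrogen, the earlier compounds carried only six-membered aromatic rings of carbon, and the step of no change at the digits printed from compound 3 to compound 4 (within the scatter) in this assay now extends the comparison to a six-membered non-aromatic ring with 4 double bonds outside aromatic rings. This change also takes the count of hydrogen-bond donors in the group from 2 to 0, yet the step of a 2.0-fold higher number from compound 1 to compound 4 (0.30 log units; within the scatter) likewise stays within the scatter, so 2,5-dimethoxyphenyl, 2,5-dihydroxyphenyl and the non-aromatic ring cannot be told apart in this read-out. Nothing available accounts for this flat outcome.

The compounds shown leave open whether any group at this carbon can move the number beyond the scatter, for instance a ring bearing an amine or a carboxylic acid, or a longer chain with no ring at all. They also leave open whether the non-aromatic ring would give the same number on the shared core with hydrogen in place of the acetylsulfamoyl group.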